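This account rests on a few compounds, and the source may have more. Where it says the series, first, only, none or still open, it means among the compounds named here.

Compound 3 `O=C(O)c1ccc(N2CCC(NS(=O)(=O)c3cc(S(=O)(=O)c4ccccc4)ccc3C(F)(F)F)CC2)cc1` gives 230 nM in an assay on U2OS cells for inhibition of secreted frizzled-related protein 1 (Homo sapiens), read by a luciferase reporter, with a stated time of 18 h (on this read-out lower numbers stand for an effect already at smaller amounts and higher numbers for an effect only at larger amounts of compound), level with compound 2 `O=C(c1ccccn1)N1CCC(NS(=O)(=O)c2cc(S(=O)(=O)c3ccccc3)ccc2C(F)(F)F)CC1` at 230 nM and a step of a 3.8-fold lower number from compound 1 to compound 3 (0.58 log units; beyond the scatter) away from compound 1 `O=C(c1cccc(Cl)c1)N1CCC(NS(=O)(=O)c2cc(S(=O)(=O)c3ccccc3)ccc2C(F)(F)F)CC1`, whose value is 870 nM. Compound 4 `O=C(C1CCNCC1)N1CCC(NS(=O)(=O)c2cc(S(=O)(=O)c3ccccc3)ccc2C(F)(F)F)CC1` differs from compound 3 by (piperidin-4-yl)carbonyl in place of 4-carboxyphenyl on an amine nitrogen in a ring. The steps at this ring nitrogen are the guide: no change at the digits printed from compound 2 to compound 3 (within the scatter) and a 3.8-fold lower number from compound 1 to compound 3 (0.58 log units; beyond the scatter). The aroyl-to-aryl exchange therefore moved the number only modestly or not at all, and compound 4 returns to a carbonyl group here, now carrying a non-aromatic ring. Among the compounds with values here, no measured compound carries a comparable group, so compound 4 is expected to sit in a similar region, with at most a modest step estimated as a 2.0-fold higher number from compound 3 to compound 4 (0.29 log units; within the scatter). The estimate for compound 4 is 450 nM, with a range of 150 nM to 1400 nM.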

Compound 4, half-maximal effective concentration: 150 nM
Estimate against measurement, compound 4: 3.0-fold (0.48 log units) above, and the stated range covers the measured number.
By their numbers in this assay, from the lowest: compounds 4, 2 and 3 (each within the scatter of the next); then compound 1.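

In this assay, a group with a non-aromatic ring serves at this ring nitrogen as well as the earlier aromatic groups, with a 1.5-fold lower number from compound 3 to compound 4 (0.19 log units; within the scatter) and a 1.5-fold lower number from compound 2 to compound 4 (0.19 log units; within the scatter) both small. Only compound 1 stands apart, with a 5.8-fold lower number from compound 1 to compound 4 (0.76 log units; beyond the scatter) showing that piperidin-4-yl on the carbonyl carbon gives a clear gain over 3-chlorophenyl. Nothing available here accounts for these steps. The compounds shown leave open whether a cyclohexyl group or an open-chain amine on the same carbonyl carbon would give a similar number.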